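A new group on the carbonyl of compound 3

The compounds below may be only part of what the source reports. "The series", "measured", "known", "first", "only" and "open" are said of these compounds alone.

Measured so far in a functional assay on MV4-11 cells (Homo sapiens) for antiproliferative activity, read by luminescence, with a stated time of 72 h (a lower number here means a stronger inhibitor, a higher number a weaker inhibitor), the compounds stand as follows:
Compound 1 `C=CS(=O)(=O)NC/C=C/c1cc(OC)cc(O)c1C(=O)OC(C)C` gives 4660 nM
Compound 2 `C=CS(=O)(=O)NC/C=C/c1cc(OC)cc(O)c1C(=O)OCc1ccc(Br)cc1` gives 6060 nM
Compound 3 `COc1cc(O)c(C(=O)OC(C)C)c(/C=C/CNC(C)=O)c1` gives > 10000 nM as a limit of the assay and not a number

Compound 3 stands at the limit of > 10000 nM in this assay, at which 1 of the 3 values shown sits, and so has no exact number. The change to compound 4 `CCN(CC)C/C=C/C(=O)NC/C=C/c1cc(OC)cc(O)c1C(=O)OC(C)C` is 3-(diethylamino)prop-1-en-1-yl in place of methyl on a carbonyl carbon and it puts 3-(diethylamino)prop-1-en-1-yl in place of methyl on a carbonyl carbon. The closest evidence comes from the group on the same amine nitrogen, where acetyl in place of vinylsulfonyl gave an at least 2.1-fold higher number from compound 1 to compound 3 (0.33 log units; beyond the scatter) in this pair. The other measured step, a 1.3-fold higher number from compound 1 to compound 2 (0.11 log units; within the scatter) in size, lies at a different place and does not bear on this change. A step of similar size toward a lower number is therefore expected in this assay although compound 4 could also remain at the limit. By this estimate the expected step is an at least 2.2-fold lower number from compound 3 to compound 4 (0.34 log units; beyond the scatter) overall. The expected value for compound 4 is 4500 nM (estimated range 1500 nM to 13000 nM).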

Compound 4, half-maximal inhibitory concentration: > 10000 nM
Compound 4: a limit, no number; the forecaster's own chance of this, stated with the estimate: 25%; middle value at least 2.2-fold (0.34 log units) away from the limit.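

Going by these compounds alone, compound 3 and compound 4 both give only a limit and not a number in this assay, so no step between them can be read: the limit of > 10000 nM in this assay, at which 2 of the 4 values shown sit. The compounds shown leave open whether 3-(diethylamino)prop-1-en-1-yl in place of methyl on a carbonyl carbon changes activity in either direction.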